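Extending the amine nitrogen of compound 3

The compounds below may be only part of what the source reports. "The series", "measured", "known", "first", "only" and "open" are said of these compounds alone.

Compound 3 `NNC(=O)CSCc1nc2cc([N+](=O)[O-])ccc2[nH]1` gives 5330 nM in a functional assay on HCT-116 cells (Homo sapiens) for cytotoxicity, read by MTT assay, with a stated time of 48 h; a higher number here means a weaker inhibitor, a lower number a stronger inhibitor. Of the two numbers shown it stands highest; its nearest neighbour, compound 1 `O=C(CSCc1nc2cc([N+](=O)[O-])ccc2[nH]1)c1ccc(Br)cc1`, gives 1780 nM in this assay, and the gap is a 3.0-fold higher number from compound 1 to compound 3 (0.48 log units; beyond the scatter). Compound 2 `CCOC(=O)CSCc1nc2cc([N+](=O)[O-])ccc2[nH]1` gives > 100000 nM in this assay, which is a limit of the assay and not a number. Compound 4 `NC(=S)NNC(=O)CSCc1nc2cc([N+](=O)[O-])ccc2[nH]1` differs from compound 3 by a group of 3 heavy atoms (1 carbon, 1 nitrogen, 1 sulfur; no ring) in place of a hydrogen atom, on an amine nitrogen. Every measured step changes the group on the carbonyl carbon: an at least 56-fold higher number from compound 1 to compound 2 (1.74 log units; beyond the scatter), an at least 18-fold lower number from compound 2 to compound 3 (1.27 log units; beyond the scatter) and a 3.0-fold higher number from compound 1 to compound 3 (0.48 log units; beyond the scatter). None of them alters the amine nitrogen, so they show only how much the numbers can move in this series, not the direction for this change. The aminoamino end of compound 3 is kept and merely lengthened in compound 4. A step of modest size at most is expected, with a lower number slightly more likely. The estimate for compound 4 is 3000 nM, with a range from 800 nM to 12000 nM. For compound 4 that estimate means an expected 1.8-fold lower number from compound 3 to compound 4 (0.25 log units; within the scatter).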

Compound 4, half-maximal inhibitory concentration: 4710 nM
Estimate against measurement, compound 4: 1.6-fold (0.20 log units) below; the range from low to high includes it.
By their numbers in this assay, from the lowest: compound 1; then compounds 4 and 3 (each within the scatter of the next). At a limit, above all of these: compound 2.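

In this assay, placing the group of 3 heavy atoms on the amine nitrogen in place of a hydrogen atom gives a 1.1-fold lower number from compound 3 to compound 4 (0.05 log units; within the scatter), so this position accepts the extension with no readable change; the extended end also stays behind the 4-bromophenyl group on the carbonyl carbon, with a 2.6-fold higher number from compound 1 to compound 4 (0.42 log units; beyond the scatter). Compound 4 thus keeps the gain that compound 3 holds over the ethoxy end, seen in an at least 21-fold lower number from compound 2 to compound 4 (1.32 log units; beyond the scatter). That step is only a bound, as the value of compound 2 is a limit of the assay and not a number: the limit of > 100000 nM in this assay, at which 1 of the 4 values shown sits.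

The compounds shown leave open whether a urea, with oxygen in place of the sulfur, would read the same as compound 4. Also open, going by these compounds, is whether a phenyl ring or a longer chain on this amine nitrogen would move the number at all.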